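Methyl on the benzoxazine ring of a flavone series

This account rests on a few compounds, and the source may have more. Where it says the series, first, only, none or still open, it means among the compounds named here.

Compound 1 `O=c1cc(-c2ccccc2)oc2cc(N3COc4ccccc4C3)ccc12` stands lowest among the three measured compounds: in a functional assay on MCF7 cells (Homo sapiens) for inhibition, read by MTT assay, with a stated time of 48 h, tested at 60 ug/mL (on this read-out lower numbers stand for less inhibition of growth and higher numbers for more inhibition of growth at the one concentration tested), compound 1 gives 19.3%. Compound 2 `Cc1cccc2c1OCN(c1ccc3oc(-c4ccccc4)cc(=O)c3c1)C2` gives 85.1% in this assay, and compound 3 `COc1cc2c(c(OC)c1)OCN(c1ccc3c(=O)cc(-c4ccccc4)oc3c1)C2` gives 88.9%, both far beyond the scatter above compound 1. Compound 4 `Cc1cccc2c1OCN(c1ccc3c(=O)cc(-c4ccccc4)oc3c1)C2` differs from compound 1 by methyl in place of hydrogen on an aromatic carbon. For the measured compounds named here, no single-change step between measured compounds exists, yet compound 1 shares its point of attachment with compound 3, which with its substituted ring gives 88.9%, so a large rise is expected. The step from compound 1 to compound 4 is estimated at a number 50.7 percentage points higher from compound 1 to compound 4 (beyond the scatter). Compound 4 is expected to reach 70%, within 35% to 95%.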

Compound 4, percent growth inhibition at one concentration: 66.6%
For compound 4 the middle estimate is 3.4 percentage points above the measured one; the range from low to high includes it.
By their numbers in this assay, from the lowest: compound 1; then compound 4; then compounds 2 and 3 (each within the scatter of the next).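

In this assay, for the compounds shown here, methyl in place of hydrogen on an aromatic carbon, ortho to a fused ring and meta to a fused ring, gives a number 47.3 percentage points higher from compound 1 to compound 4 (beyond the scatter), the only single-change step in this set. It shows that this position responds strongly to the methyl alone, with no other change to the core of compound 1. Nothing measured here explains the rise.

As far as these compounds go, whether an ethyl group, a longer chain or an amine at this carbon would keep the rise remains open, as does the effect of a methyl on the other carbons of this ring.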